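The source may hold more compounds than are shown below. What is called first, only, known or untested is meant among the compounds shown, and "the series" means these compounds.

Measured compounds:
Compound 1, `CC(C)(C)OC(=O)N1CCC(CCCNc2ccc3c(c2)OCCS3(=O)=O)CC1` — "not determined" (no result reported) in a functional assay on CHO-K1 cells for agonist activity at Glucose-dependent insulinotropic receptor (Mus musculus), read by HTRF and cAMP accumulation, with a stated time of 30 min; a lower number here means that less compound is needed, a higher number that more compound is needed for the effect.
Compound 2, `CC(C)(C)OC(=O)N1CCC(CCCNc2ccc3c(c2)OCC3=O)CC1` — 66 nM in this assay.
Compound 3, `CC(C)(C)OC(=O)N1CCC(CCCNc2ccc3c(c2)CNC3=O)CC1` — 515 nM in this assay.

Two of the three compounds give a number in this assay; for compound 1 no result was reported. Among the two numbers, compound 2 stands lowest, and its nearest neighbour, compound 3, lies well above it, beyond the usual scatter of repeated measurements. No pair of these compounds differs in a single place, so the gap between compound 2 and compound 3 is stated only as the two values show it.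

Compound 4, `CC(C)c1nsc(N2CCC(CCCNc3ccc4c(c3)OCC4=O)CC2)n1`, is not yet measured in this assay. It differs from compound 2 in one place: 3-isopropyl-1,2,4-thiadiazol-5-yl in place of tert-butoxycarbonyl on an amine nitrogen in a ring. The shared core of compound 2, with its amine-linked chain, is kept unchanged.

Going by the values given here, nothing among the measured compounds shows what such a change does in this assay, since no step of this kind is recorded. The expectation therefore rests on compound 2 alone, and the step from compound 2 to compound 4 is expected to be a 1.9-fold lower number from compound 2 to compound 4 (0.28 log units; within the scatter), a modest move towards a lower number that may not exceed the scatter. Compound 4 is expected to give 35 nM, with a range from 8 nM to 150 nM.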

Compound 4, half-maximal effective concentration: 812 nM
The estimate for compound 4 lay 23-fold (1.37 log units) below the measured number; the measured number lies above the stated range.
By their numbers in this assay, from the lowest: compound 2; then compounds 3 and 4 (each within the scatter of the next).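

Going by these compounds alone, on the amine nitrogen of the six-membered non-aromatic ring, 3-isopropyl-1,2,4-thiadiazol-5-yl in place of tert-butoxycarbonyl gives a 12-fold higher number from compound 2 to compound 4 (1.09 log units; beyond the scatter) in this assay, the only step here that can be read at a single place. The group on this nitrogen therefore matters to the read-out even with the shared core and its amine-linked chain unchanged, and of these two groups, tert-butoxycarbonyl goes with the lower number, so that less compound is needed for the effect. No measurement given here bears on why the number rises with this change.

As far as these compounds go, one step cannot separate the loss of the carbamate from the entry of the aromatic ring, so it remains open whether an isopropyl carbamate, a pyrimidin-2-yl group or a 3-isopropyl-1,2,4-oxadiazol-5-yl group on the same nitrogen would stay close to compound 2 or move towards compound 4. From the compounds shown here alone, it also remains open whether 3-isopropyl-1,2,4-thiadiazol-5-yl would produce a step of similar size on the core of compound 3 or on that of compound 1.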